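The source may hold more compounds than are shown below. What is called first, only, known or untested is meant among the compounds shown, and "the series" means these compounds.

Compound 1 `Cc1cn([C@@H]2O[C@H](CO[Si](C)(C)C(C)(C)C)[C@@]3(OS(=O)(=O)C=C3NCC(=O)C(=O)N3CCC3)[C@H]2O[Si](C)(C)C(C)(C)C)c(=O)n(C)c1=O`: 17400 nM
Compound 2 `C=C(C)C(=O)NC(=O)NC1=CS(=O)(=O)O[C@@]12[C@@H](CO[Si](C)(C)C(C)(C)C)O[C@@H](n1cc(C)c(=O)n(C)c1=O)[C@@H]2O[Si](C)(C)C(C)(C)C`: 1190 nM
Compound 3 `Cc1cn([C@@H]2O[C@H](CO[Si](C)(C)C(C)(C)C)[C@@]3(OS(=O)(=O)C=C3NC(=O)NC(=O)c3ccccc3)[C@H]2O[Si](C)(C)C(C)(C)C)c(=O)n(C)c1=O`: 3330 nM

In a functional assay on MT4 cells (Homo sapiens) (on this read-out higher numbers stand for lower toxicity in this test and lower numbers for higher toxicity in this test), compound 2 stands lowest of the three numbers; the nearest is compound 3, with a 2.8-fold higher number from compound 2 to compound 3 (0.45 log units; beyond the scatter), and the furthest is compound 1, from which a 15-fold lower number from compound 1 to compound 2 (1.17 log units; beyond the scatter). Compound 4 `Cc1cn([C@@H]2O[C@H](CO[Si](C)(C)C(C)(C)C)[C@@]3(OS(=O)(=O)C=C3NCCC(N)=O)[C@H]2O[Si](C)(C)C(C)(C)C)c(=O)n(C)c1=O` differs from compound 2 by 2-carbamoylethyl in place of ((1-methylethenyl)carbonyl)carbamoyl on an amine nitrogen. Within the data shown here, the only step that bears on a plain chain on this amine nitrogen is that from compound 1 to compound 2, which was large; a chain without the acylcarbamoyl group is therefore expected to move the number back up, roughly toward compound 1. Compound 4 is thus estimated at 10000 nM, with a range from 3000 nM to 30000 nM, corresponding to an expected 8.4-fold higher number from compound 2 to compound 4 (0.92 log units; beyond the scatter).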

Compound 4, half-maximal cytotoxic concentration: 20000 nM
Compound 4: middle estimate off by 2.0-fold (0.30 log units), on the low side; low and high end bracket the measured number.
By their numbers in this assay, from the lowest: compound 2; then compound 3; then compounds 1 and 4 (each within the scatter of the next).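

On the amine nitrogen of the shared core in this assay, 2-carbamoylethyl in place of the ((1-methylethenyl)carbonyl)carbamoyl group gives a 17-fold higher number from compound 2 to compound 4 (1.23 log units; beyond the scatter) and in place of benzoylcarbamoyl gives a 6.0-fold higher number from compound 3 to compound 4 (0.78 log units; beyond the scatter). Compounds 1 and 4, with different chains on this nitrogen, show a 1.1-fold higher number from compound 1 to compound 4 (0.06 log units; within the scatter). Both stand apart from compounds 2 and 3 by similar margins. Nothing available explains this difference. On these data alone, it remains open whether a simple acetyl group on this nitrogen would bring the number down as the two carbamoyl-linked acyl groups do, and whether a carboxylic acid at the end of the saturated chain would leave it where compounds 1 and 4 stand.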